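Methoxy in Place of Fluoro on an Aromatic Carbon

The compounds below may be only part of what the source reports. "The series", "measured", "known", "first", "only" and "open" are said of these compounds alone.

Going by the values given here, only two compounds have numbers so far. In a functional assay on KB cells (Homo sapiens) for inhibition, read by MTT assay, with a stated time of 24 h, tested at 1 ug/mL (on this read-out higher numbers stand for more inhibition of growth at the one concentration tested and lower numbers for less inhibition of growth), compound 1 (`CC(=O)SCCC(CCCCC(=O)O)SC(C)=O`) gives 12.4% and compound 2 (`O=C(CCCCC(S)CCS)Nc1ccc(F)cc1`) gives 8.84% at the single concentration tested, so compound 2 stands within the usual scatter of compound 1, and neither can be ranked above the other. Compound 3 (`COc1ccc(NC(=O)CCCCC(S)CCS)cc1`) keeps the core of compound 2 but carries methoxy in place of fluoro on an aromatic carbon, para to a large group (methoxy in place of fluoro on an aromatic carbon). Among the compounds with values here, no measured pair shows what this swap does, so the data offer no direct guide. No change beyond the scatter is expected in this assay, and no firm direction can be given: the estimated shift a number 1.2 percentage points higher from compound 2 to compound 3 (within the scatter) is small. For compound 3 the expected reading is 10%, with an estimated range from 2% to 22% in this test.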

Compound 3, percent growth inhibition at one concentration: 2.49%
Estimate against measurement, compound 3: 7.5 percentage points above; measured number inside the range.
By their numbers in this assay, from the lowest: compounds 3, 2 and 1 (each within the scatter of the next).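

Going by these compounds alone, this is the first measured swap at this place on the aromatic ring, para to a large group. In this assay, putting methoxy in place of fluoro gives a number 6.4 percentage points lower from compound 2 to compound 3 (within the scatter), so the two groups cannot be told apart here at the one concentration tested. A swap that enters with a hydrogen-bond acceptor and a larger group on this carbon therefore leaves no readable mark on growth inhibition in this test, and no measurement here offers an explanation for the numbers.

Going by these compounds, whether an amine or a carboxylic acid on this same carbon, or a longer chain in place of methoxy, would give a step beyond the scatter remains open. Also open, on these data alone, is whether fluoro and methoxy would separate at other concentrations or at other places on the ring.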